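Ester trimming in a terpenoid series: cyclopropylmethyl to methyl

The source may report more compounds than this note shows. Statements on the series, on what has been measured and on what is new or still open speak of the compounds shown alone.

Measured so far:
- compound 1 `C=C(C)[C@H]1CC=C(C)C2=CO[C@@H](c3ccccc3F)[C@@H]21`: 1000 nM
- compound 2 `C=C(C)[C@H]1CC=C(C)[C@@]2(O)[C@@H]1[C@H](c1ccccc1Br)O[C@@H]2C(=O)OCC1CC1`: 50000 nM
- compound 3 `C=C(C)[C@H]1CC(=O)C(C)=C2[C@@H](C(=O)OCC)O[C@@H](c3cccc(Cl)c3Cl)[C@@H]21`: 5000 nM

In a functional assay on KB3 cells (Homo sapiens) for antiproliferative activity, read by MTT assay, with a stated time of 96 h (a lower number here means a stronger inhibitor, a higher number a weaker inhibitor), compound 2 gives 50000 nM, the highest number of the three and therefore the weakest inhibitor here; compound 3 sits well below it, and compound 1 further still, both gaps beyond the usual scatter. Compound 4 `C=C(C)[C@H]1CC=C(C)[C@@]2(O)[C@@H]1[C@H](c1ccccc1Br)O[C@@H]2C(=O)OC` is not yet measured. It differs from compound 2 by one change: hydrogen in place of cyclopropyl on a saturated chain carbon bound to an oxygen next to a carbonyl group. Going by the values given here, no measured pair shows what this kind of trimming does, so there is no direct guide. The expectation is a step from compound 2 to compound 4 of a 1.3-fold lower number from compound 2 to compound 4 (0.10 log units; within the scatter), small and not clearly beyond the scatter. Compound 4 is therefore expected to give about 40000 nM, with a likely range from 15000 nM to 100000 nM.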

Compound 4, half-maximal inhibitory concentration: 5000 nM
For compound 4 the middle estimate is 8.0-fold (0.90 log units) above the measured one; measured number outside the range, below it.
By their numbers in this assay, from the lowest: compound 1; then compounds 3 and 4 (each within the scatter of the next); then compound 2.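

Going from cyclopropylmethoxycarbonyl to methoxycarbonyl gives a 10-fold lower number from compound 2 to compound 4 (1.00 log units; beyond the scatter) in this assay, the first direct sign that this ester group affects antiproliferative strength. The cyclopropyl group is therefore not needed for activity in this series, and inhibition is stronger without it. Nothing shown here explains the gain.

This single pair cannot show whether the trend extends to other replacements. A carboxylic acid or an amide in place of the methyl ester could strengthen or weaken inhibition.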